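This account rests on a few compounds, and the source may have more. Where it says the series, first, only, none or still open, it means among the compounds named here.

The measured compounds are three:

compound 1, `COc1cc(Cl)cc(-c2nn(-c3cccc(NC(=O)Nc4ccc(Cl)c(C(F)(F)F)c4)c3)cc2-c2ccncc2)c1`, giving 95% in a functional assay on SNB-19 cells (Homo sapiens) for inhibition, read by sulforhodamine B assay, with a stated time of 48 h, tested at 0.1 uM; a higher number here means a weaker effect of the compound at the concentration tested, a lower number a stronger effect;
compound 2, `COc1cc(Cl)cc(-c2nn(-c3cccc(NC(=O)Nc4cc(C(F)(F)F)cc(C(F)(F)F)c4)c3)cc2-c2ccncc2)c1`, giving 87% in this assay;
compound 3, `COc1cc(Cl)cc(-c2nn(-c3cccc(NC(=O)Nc4ccc(Cl)c(Cl)c4)c3)cc2-c2ccncc2)c1`, giving 90% in this assay.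

Compound 3 stands second among the three numbers; its nearest neighbour is compound 2, its furthest compound 1, and both gaps lie within the scatter of repeated measurements. Among the compounds with values here, the one step measured across a single change, a number 5 percentage points lower from compound 1 to compound 3 (within the scatter), is also within the scatter.

Compound 4, `COc1cc(Cl)cc(-c2nn(-c3cccc(NC(=O)Nc4cccc(C(F)(F)F)c4)c3)cc2-c2ccncc2)c1`, has not yet been measured. It differs from compound 3 in this way: 3-(trifluoromethyl)phenyl in place of 3,4-dichlorophenyl on an amide-type nitrogen. The change again exchanges chloro and trifluoromethyl on the urea-bearing phenyl ring and removes one chloro. Within the data shown here, the only measured step of related kind, a number 5 percentage points lower from compound 1 to compound 3 (within the scatter), was within the scatter, and all three measured values sit close together in this assay. No step beyond the scatter is therefore expected, and compound 4 is estimated to give about 91% in this assay, within 80% to 100%, an expected change of a number 1 percentage points higher from compound 3 to compound 4 (within the scatter).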

Compound 4, a percentage reported as activity, at one concentration (the size of the read-out at that concentration, not a potency): 96%
Beside the measured number, compound 4's estimate is 5 percentage points below it; the measured number falls inside the stated range.
By their numbers in this assay, from the lowest: compounds 2, 3, 1 and 4 (each within the scatter of the next).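

Exchanging 3,4-dichlorophenyl for 3-(trifluoromethyl)phenyl on the amide-type nitrogen gives a number 6 percentage points higher from compound 3 to compound 4 (within the scatter) in this assay, so this change of the whole aryl group, with its two substituents replaced by one, leaves the read-out within the scatter. Removing a single substituent from the ring is now measured as well: hydrogen in place of trifluoromethyl gives a number 9 percentage points higher from compound 2 to compound 4 (within the scatter) and hydrogen in place of chloro gives a number 1 percentage points higher from compound 1 to compound 4 (within the scatter), and neither step lies beyond the scatter. No measurement bearing on the reason for these results is available.

What the compounds shown leave open is whether any group at this place can move the number in this assay beyond the scatter. A carboxylic acid or an amine on this phenyl ring, or a longer chain in place of the ring, would be untested ground here, as would any change to the shared core.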